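The compounds below may be only part of what the source reports. "The series", "measured", "known", "first", "only" and "open" are said of these compounds alone.

Compound 1 `N#CC1CN1C(=O)Nc1ccc(F)cc1`: 2400 nM
Compound 2 `N#CC1CN1C(=O)Nc1ccccc1`: 2600 nM

Both were tested in a functional assay on MCF7 cells (Homo sapiens) for inhibition; a higher number here means a weaker inhibitor, a lower number a stronger inhibitor. Compound 2 stands at one end of this pair of numbers, but the step of a 1.1-fold higher number from compound 1 to compound 2 (0.03 log units; within the scatter) lies within the scatter, so the two compounds cannot be told apart on these values.

Compound 3 `N#CC1CN1C(=O)Nc1ccc(S(N)(=O)=O)cc1` is the next compound, differing from compound 2 in one place: sulfamoyl in place of hydrogen on an aromatic carbon. Within the data shown here, the only measured step, the exchange of fluoro for hydrogen on an aromatic carbon from compound 1 to compound 2, was within the scatter. Among the measured compounds shown here, that step is the sole guide here, and it does not cover a group like sulfamoyl, which brings a hydrogen-bond donor and two acceptors. The expectation therefore rests on little: no step beyond the scatter is expected in this assay, with a wide range either way.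

For compound 3 the expected result in this assay is 2500 nM, within 700 nM to 9000 nM. This estimate corresponds to an expected step of a 1.0-fold lower number from compound 2 to compound 3 (0.02 log units; within the scatter).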

Compound 3, half-maximal inhibitory concentration: > 15000 nM
Compound 3 gave a limit, no number; the forecaster's own chance of this, stated with the estimate: 10%; middle value at least 6.0-fold (0.77 log units) from the limit.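

Fluoro and hydrogen on this aromatic carbon could not be told apart in this assay, with a 1.1-fold higher number from compound 1 to compound 2 (0.03 log units; within the scatter) as the only earlier step, but that does not hold for every group placed there. Sulfamoyl in place of hydrogen gives an at least 5.7-fold higher number from compound 2 to compound 3 (0.76 log units; beyond the scatter) and sulfamoyl in place of fluoro gives an at least 6.2-fold higher number from compound 1 to compound 3 (0.79 log units; beyond the scatter), so this position does respond to the group it carries and the change weakens inhibition. Compound 3 gives > 15000 nM, which is a limit of the assay and not a number: the limit of > 15000 nM in this assay, at which 1 of the 3 values shown sits.

With sulfamoyl the only large group shown at this carbon, it remains unclear whether the loss belongs to sulfamoyl itself or to any group of similar bulk. Going by these compounds, whether an amine, a carboxylic acid or a longer chain at the same place would keep the inhibition of compound 2 also stays open.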